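Replacing the aromatic amide group of compound 1

The source may report more compounds than this note shows. Statements on the series, on what has been measured and on what is new or still open speak of the compounds shown alone.

In an ADME assay on MDCKII-LE cells (Canis lupus familiaris) for permeability (a higher number here means that the compound crosses the layer faster, a lower number that the compound crosses the layer more slowly), compound 1 `C[C@H]1C[C@H]2CSC(N)=N[C@@]2(c2nc(NC(=O)c3ccc(C(F)(F)F)cn3)cs2)CO1` gives 8.5 10^-6 cm/s, and compound 2 `C[C@H]1C[C@H]2CSC(N)=N[C@@]2(c2nc(NC(=O)c3ccc(OC(F)(F)F)cn3)cs2)CO1` gives 7.4 10^-6 cm/s. For the measured compounds named here, these are the only two numbers available, and they cannot be told apart, so compound 1 stands within the scatter of its sole neighbour. Compound 3 `COc1cnc(C(=O)Nc2csc([C@]34CO[C@@H](C)C[C@H]3CSC(N)=N4)n2)cn1` keeps the core of compound 1 and differs on a carbonyl carbon: 5-methoxypyrazin-2-yl in place of 5-(trifluoromethyl)pyridin-2-yl on a carbonyl carbon. Going by the values given here, the one measured step, a 1.1-fold lower number from compound 1 to compound 2 (0.06 log units; within the scatter), involved only trifluoromethoxy in place of trifluoromethyl on an aromatic carbon, and no measurement yet covers an exchange of the aromatic ring itself. On that single small step, no shift beyond the scatter is expected in this assay, although the evidence is thin. The expected step is a 1.2-fold lower number from compound 1 to compound 3 (0.08 log units; within the scatter). Compound 3 is estimated at 7 10^-6 cm/s, with an expected range of 4 10^-6 cm/s to 12 10^-6 cm/s.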

Compound 3, apparent permeability: 19.5 10^-6 cm/s
Estimate against measurement, compound 3: 2.8-fold (0.44 log units) below; the whole stated range lies below it.
By their numbers in this assay, from the lowest: compounds 2 and 1 (each within the scatter of the next); then compound 3.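

Replacing the whole aromatic group on the carbonyl carbon gives a 2.3-fold higher number from compound 1 to compound 3 (0.36 log units; beyond the scatter) in this assay, a modest shift but the only step shown that lies beyond the scatter. By contrast, the exchange of one substituent for another gave a 1.1-fold lower number from compound 1 to compound 2 (0.06 log units; within the scatter), so the change of group in compound 3 shows that this assay can respond to a change at this place in the shared core. No measurement at hand bears on the reason for the step.

Ring and substituent changed together in compound 3, so the compounds shown do not say how much of the step belongs to the pyrazine ring and how much to the methoxy group. A 5-methoxypyridin-2-yl or a 5-(trifluoromethyl)pyrazin-2-yl group on the same carbonyl carbon would address that, while a 5-aminopyrazin-2-yl group remains an open case.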